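The source may hold more compounds than are shown below. What is called first, only, known or untested is meant among the compounds shown, and "the series" means these compounds.

In a functional assay on U-87MG ATCC cells (Homo sapiens) for inhibition, read by MTT assay, with a stated time of 72 h (a lower number here means a stronger inhibitor, a higher number a weaker inhibitor), three compounds that share one core have been measured. Compound 1 `COc1cc2c(Oc3ccc(NC(=O)c4nn(-c5ccccc5)c(=O)cc4C)cc3F)ccnc2cc1OCCCN1CCCC1` gives 1100 nM. Compound 2 `COc1cc2c(Oc3ccc(NC(=O)c4nn(-c5ccccc5C)c(=O)cc4C)cc3F)ccnc2cc1OCCCN1CCCC1` gives 2960 nM. Compound 3 `COc1cc2c(Oc3ccc(NC(=O)c4nn(-c5ccccc5OC(F)(F)F)c(=O)cc4C)cc3F)ccnc2cc1OCCCN1CCCC1` gives 1280 nM, which places it second highest of the three numbers: its nearest neighbour is compound 1, and the step of a 1.2-fold higher number from compound 1 to compound 3 (0.07 log units; within the scatter) lies within the scatter, while the step of a 2.3-fold lower number from compound 2 to compound 3 (0.36 log units; beyond the scatter) is beyond it and modest. The step of a 2.7-fold higher number from compound 1 to compound 2 (0.43 log units; beyond the scatter) is the only one so far that clearly moved the number.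

Compound 4 `COc1ccc(-n2nc(C(=O)Nc3ccc(Oc4ccnc5cc(OCCCN6CCCC6)c(OC)cc45)c(F)c3)c(C)cc2=O)cc1` differs from compound 3 in one place: 4-methoxyphenyl in place of 2-(trifluoromethoxy)phenyl on an aromatic nitrogen. Within the data shown here, none of the measured steps exchanges one whole substituted phenyl ring for another, so the measured steps bear on it only loosely. Among the measured compounds shown here, all three numbers so far sit close together, and the two steps involving compound 3 show that changes on this phenyl ring shifted the number at most modestly. The step from compound 3 to compound 4 is therefore expected to be small, a 1.0-fold higher number from compound 3 to compound 4 (0.01 log units; within the scatter), with no clear direction. Compound 4 is estimated at 1300 nM, with a range from 500 nM to 3500 nM.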

Compound 4, half-maximal inhibitory concentration: 2960 nM
Compound 4: middle estimate off by 2.3-fold (0.36 log units), on the low side; the measured number falls inside the stated range.
By their numbers in this assay, from the lowest: compounds 1 and 3 (each within the scatter of the next); then compounds 2 and 4 (each within the scatter of the next).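

In this assay, a 2.7-fold higher number from compound 1 to compound 4 (0.43 log units; beyond the scatter) shows that a methoxy group on the phenyl ring also raises the number, so the methyl of compound 2 is no longer the only substituent on this ring to do so, while compound 3 goes against this trend by staying within the scatter of compound 1. Among these compounds, the ring is also less tolerant of exchange than the earlier steps suggested: a 2.3-fold higher number from compound 3 to compound 4 (0.36 log units; beyond the scatter), whereas no change at the digits printed from compound 2 to compound 4 (within the scatter), so 4-methoxyphenyl and 2-methylphenyl give matching numbers. No supporting data explain these differences.

Methoxy appears here only as 4-methoxyphenyl and trifluoromethoxy only as 2-(trifluoromethoxy)phenyl, so the effect of the group cannot be separated from that of its place on the ring. Going by these compounds, a 2-methoxyphenyl or a 4-(trifluoromethoxy)phenyl ring would pull these apart, and how an amine or a carboxylic acid on this ring would fare also remains open.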